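This account rests on a few compounds, and the source may have more. Where it says the series, first, only, none or still open, it means among the compounds named here.

Three compounds share one core and differ only in the group on one aromatic carbon of it. Compound 1 `CC(C)Cc1ccc2c(NCCCNCc3ccco3)ccnc2c1` in a physicochemical assay for acid dissociation, gives 9.47. Compound 2 `c1ccc(-c2ccc3c(NCCCNCc4ccco4)ccnc3c2)cc1` in this assay gives 9.47, and compound 3 `CC(C)CCc1ccc2c(NCCCNCc3ccco3)ccnc2c1` in this assay gives 9.47, so compound 3 stands level with compounds 1 and 2 at the digits shown. The three steps among them agree: no change at the digits printed from compound 1 to compound 2 (within the scatter), no change at the digits printed from compound 1 to compound 3 (within the scatter) and no change at the digits printed from compound 2 to compound 3 (within the scatter).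

Compound 4 `Fc1ccc(Oc2ccc3c(NCCCNCc4ccco4)ccnc3c2)cc1` is the next member. The change from compound 3 is 4-fluorophenoxy in place of isopentyl on an aromatic carbon. Two of the measured steps swap the group on that same aromatic carbon, and each was without change beyond the scatter; the swap on the saturated chain was likewise without change. The step from compound 3 is therefore expected to be no change at the digits printed from compound 3 to compound 4 (within the scatter), nothing beyond the scatter. Compound 4 is estimated at 9.47 in this assay, with a range from 9.15 to 9.75.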

Compound 4, acid dissociation constant: 9.28
Compound 4: the middle estimate sits 0.19 log units above what was measured; the range from low to high includes it.
By their numbers in this assay, from the lowest: compounds 4, 1, 2 and 3 (each within the scatter of the next).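

In this assay, for the compounds shown here, 4-fluorophenoxy on this aromatic carbon is the first group whose printed digits differ from the others, and every comparison stays inside the scatter: the series shows a number 0.19 log units lower from compound 3 to compound 4 (within the scatter) against isopentyl, a number 0.19 log units lower from compound 2 to compound 4 (within the scatter) against phenyl and a number 0.19 log units lower from compound 1 to compound 4 (within the scatter) against isobutyl. The groups compared at this position now include one that brings a hydrogen-bond acceptor as well as an aromatic ring, and none of the steps to it lies beyond the scatter. No supporting information bears on the difference in digits.

On these data alone, whether an amine or a carboxylic acid on this aromatic carbon would give a step beyond the scatter remains open. As far as these compounds go, all four compounds also keep the rest of the shared core alike, so the effect of a longer chain in place of the one they all carry is also open.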